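Adding a Second Chloro Group on the Shared Core

The source may report more compounds than this note shows. Statements on the series, on what has been measured and on what is new or still open speak of the compounds shown alone.

Of the compounds shown here, three have been measured so far. Compound 1 `ClCc1cccc(Cn2cnc3ncnc(Cl)c32)c1` and compound 2 `ClCc1cccc(Cn2cnc3c(Cl)ncnc32)c1` carry a single chloro group on the shared core; the two have the same atoms joined differently, and the difference between the two cores is not broken down here. Compound 3 `ClCc1cccc(Cn2cnc3c(Cl)nc(Cl)nc32)c1` carries a second chloro group. In a functional assay on SF-539 cells (Homo sapiens) for cytotoxicity, read by sulforhodamine B assay, with a stated time of 48 h (on this read-out lower numbers stand for stronger inhibition of growth and higher numbers for weaker inhibition of growth), compound 1 gives 20000 nM, and compound 2 gives 20000 nM, so these two cannot be told apart. Compound 3 gives 2180 nM. The change chloro in place of hydrogen on an aromatic carbon produced a 9.2-fold lower number from compound 2 to compound 3 (0.96 log units; beyond the scatter).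

Compound 4 `ClCc1cccc(Cn2cnc3nc(Cl)nc(Cl)c32)c1` has not yet been measured. For the measured compounds named here, it arises from compound 1 by the change (chloro in place of hydrogen on an aromatic carbon), which is the same change as the one from compound 2 to compound 3, made at the same kind of place on the core. Because compound 2 to compound 3 gave a 9.2-fold lower number from compound 2 to compound 3 (0.96 log units; beyond the scatter), a step of similar size is expected here, a 6.7-fold lower number from compound 1 to compound 4 (0.82 log units; beyond the scatter), though it rests on a single measured example. Compound 4 is therefore estimated at 3000 nM, with a plausible range from 1000 nM to 12000 nM.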

Compound 4, concentration for 50% growth inhibition: 160 nM
Compound 4: the middle estimate sits 19-fold (1.27 log units) above what was measured; measured number outside the range, below it.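

In this assay, placing a chloro group on the aromatic carbon between two ring nitrogen atoms gives a 130-fold lower number from compound 1 to compound 4 (2.10 log units; beyond the scatter), so the number falls on both cores, but the size of the step does not carry over from one core to the other: the same change on two cores in this assay, a 9.2-fold lower number (0.96 log units; beyond the scatter) from compound 2 to compound 3 and a 130-fold lower number (2.10 log units; beyond the scatter) from compound 1 to compound 4, 14-fold (1.13 log units) apart, beyond the scatter of two such steps

In these two pairs, a step measured on one core gave the right direction on the other but not a dependable size. The data do not show why the two steps differ, and two pairs cannot say how this change would behave on any further core.

The compounds shown have only hydrogen or chloro at this place, so it remains open whether an amine or a methoxy group there would also lower the number. Also open, as far as these compounds go, is whether the gap between the two steps would persist if a hydroxymethyl group took the place of the chloromethyl group shared by all four compounds.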